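Benzyl in place of allyl on the shared core

The compounds below may be only part of what the source reports. "The series", "measured", "known", "first", "only" and "open" are said of these compounds alone.

Compound 1 `C=CCNc1nc(N)c(C(=O)N=C(N)N)nc1Cl` carries the shared core with allyl on a nitrogen on an aromatic ring. In an assay for inhibition of acid-sensing ion channel 3 (Homo sapiens), read by patch clamp, tested at 20 uM (a higher number here means more inhibition at the concentration tested (going by the name of the read-out), a lower number less inhibition), compound 1 gives 78%, the highest of the two numbers available. Among the measured compounds shown here, compound 2 `CC(C)(C)Nc1nc(N)c(C(=O)N=C(N)N)nc1Cl` gives 48%; the step of a number 30 percentage points lower from compound 1 to compound 2 (beyond the scatter) is the only measured change in this set, tert-butyl in place of allyl on that ring nitrogen. Compound 3 `NC(N)=NC(=O)c1nc(Cl)c(NCC2CCc3ccccc3C2)nc1N`, with a fused bicyclic group on the same side chain, gives "not determined" (no result reported) in this assay, so no number is reported for it.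

Compound 4 `NC(N)=NC(=O)c1nc(Cl)c(NCc2cccc(F)c2)nc1N` differs from compound 1 by 3-fluorophenyl in place of vinyl on a saturated chain carbon bound to a nitrogen on an aromatic ring. For the measured compounds named here, no measured step bears on this change directly: the step from compound 1 to compound 2 alters the group on the ring nitrogen itself, not the saturated chain carbon, and compound 3, the only other branch-point change, gives no number. Given that the one measured change lowered inhibition, a step of similar or smaller size, downward or none beyond the scatter, is expected: a number 13 percentage points lower from compound 1 to compound 4 (beyond the scatter). Compound 4 is therefore estimated at 65%, in the range 35% to 90%.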

Compound 4, a percentage reported as inhibition, at one concentration (the size of the read-out at that concentration, not a potency): 90%
Compound 4: middle estimate off by 25 percentage points, on the low side, and the stated range covers the measured number.
By their numbers in this assay, from the lowest: compound 2; then compound 1; then compound 4.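

In this assay, the saturated chain carbon bound to a nitrogen on an aromatic ring accepts 3-fluorophenyl, with 7 heavy atoms, in place of vinyl, with 2, and the change gives a number 12 percentage points higher from compound 1 to compound 4 (beyond the scatter) rather than a loss. Set against a number 30 percentage points lower from compound 1 to compound 2 (beyond the scatter), this shows that changing the group on that nitrogen can move inhibition in either direction, and compound 4 is the first change here to raise it. No measurement at hand accounts for the rise.

On these data alone, what the fluorine itself contributes remains open, and a plain phenyl or a 3-methoxyphenyl at the same place would address that. Also open, as far as these compounds go, is how the series responds to an amine or a carboxylic acid on this chain, or to a longer chain carrying the aromatic ring.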